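Trifluoromethyl on the Phenyl of an Imidazolylpropylguanidine

The source may report more compounds than this note shows. Statements on the series, on what has been measured and on what is new or still open speak of the compounds shown alone.

The series shares a guanidine core carrying an imidazolylpropyl chain, with the second arm ending in a carbon that bears both a phenyl and a pyridyl ring. Compound 1 `N=C(NCCCc1c[nH]cn1)NCCSC(c1ccccc1)c1ccccn1` links that carbon through a thioether, and in a functional assay on ileum for antagonist activity at histamine H1 receptor (Cavia porcellus) (a higher number here means weaker binding, a lower number tighter binding), compound 1 gives 100 nM. Compound 2 `N=C(NCCCc1c[nH]cn1)NCCC(c1ccccc1)c1ccccn1` replaces the thioether with a methylene, and in this assay compound 2 gives 97.7 nM. The two values sit within the usual scatter of each other, so the data show no difference between them; compound 2 simply holds the lowest of the two numbers on record. Compound 3 `N=C(NCCCc1c[nH]cn1)NCCC(c1ccc(C(F)(F)F)cc1)c1ccccn1` differs from compound 2 by trifluoromethyl in place of hydrogen on an aromatic carbon. Among the compounds with values here, no measured pair reports such a change, so the author expects the step from compound 2 to compound 3 in this assay, a 1.4-fold lower number from compound 2 to compound 3 (0.14 log units; within the scatter), to stay small, with a lean toward a lower number. Compound 3 is estimated at 70 nM, within a range from 20 nM to 250 nM.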

Compound 3, dissociation constant: 282 nM
Estimate against measurement, compound 3: 4.0-fold (0.61 log units) below; the measured number lies above the stated range.
By their numbers in this assay, from the lowest: compounds 2 and 1 (each within the scatter of the next); then compound 3.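

In this assay, within the data shown here, trifluoromethyl in place of hydrogen on an aromatic carbon, para to a large group, gives a 2.9-fold higher number from compound 2 to compound 3 (0.46 log units; beyond the scatter), and this is the only step between compounds that differ in one place that is printed as beyond the scatter. The phenyl ring therefore does respond to a change at this carbon, and here the response is toward weaker binding, although the step is modest. Nothing in the available data accounts for this shift.

The compounds shown leave open whether a single fluorine, a chlorine or a methyl at the same carbon would move the number in the same direction. They also leave open whether trifluoromethyl would have a similar effect on the thioether-linked compound 1 or on the pyridine ring.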